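Swapping a hydroxymethyl for a chloro on a shared core

The compounds below may be only part of what the source reports. "The series", "measured", "known", "first", "only" and "open" are said of these compounds alone.

Compound 1 `C=CCc1ccc(OCc2cn(-c3ccccc3CO)nn2)c(O)c1` and compound 2 `C=CCc1cc(O)c(O)c(CN2CCC(CO)CC2)c1` have both been tested in a functional assay on MIA PaCa-2 cells (Homo sapiens) for inhibition, read by MTT assay, with a stated time of 72 h, tested at 30 uM; a higher number here means more inhibition of growth at the concentration tested, a lower number less inhibition of growth. Compound 1 gives 39.6%, and compound 2 gives 34.1%, a gap that lies within the usual scatter, so the two compounds stand side by side on these numbers. Compound 3 `C=CCc1ccc(OCc2cn(-c3ccccc3Cl)nn2)c(O)c1` is the untested one; it differs from compound 1 by chloro in place of hydroxymethyl on an aromatic carbon. Among the compounds with values here, with no measured pair showing this change, the step is expected to be small, a number 2.4 percentage points higher from compound 1 to compound 3 (within the scatter), in no clear direction beyond the scatter. Compound 3 is therefore expected to give about 42%, between 25% and 60%.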

Compound 3, percent growth inhibition at one concentration: 46.6%
Beside the measured number, compound 3's estimate is 4.6 percentage points below it, and the stated range covers the measured number.
By their numbers in this assay, from the lowest: compounds 2, 1 and 3 (each within the scatter of the next, the first and the last beyond it).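

Chloro in place of hydroxymethyl on this aromatic carbon gives a number 7 percentage points higher from compound 1 to compound 3 (within the scatter) in this assay, so this ortho position tolerates the swap without a step beyond the scatter. The read-out holds even though the hydrogen-bond donor and acceptor counted for hydroxymethyl leave with it. No measurement at hand explains this result. The compounds shown leave open how an amine or a carboxylic acid on this same aromatic carbon would read. They also leave open whether a longer chain there would produce a step beyond the scatter.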